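A Smaller Group on the Ring Nitrogen

The source may report more compounds than this note shows. Statements on the series, on what has been measured and on what is new or still open speak of the compounds shown alone.

Among the compounds with values here, compound 3 `CC(C)n1c(/C=C2/C(=O)Nc3ccc(Cl)cc32)nc2ccccc21` gives 38100 nM in a functional assay on PC-3 cells (Homo sapiens) for cytotoxicity, read by MTT assay, with a stated time of 48 h (a lower number here means a stronger inhibitor, a higher number a weaker inhibitor), the only number among the three values shown. Compound 1 `Cn1c(/C=C2/C(=O)Nc3ccc([N+](=O)[O-])cc32)nc2ccccc21` sits at the limit > 50000 nM in this assay. Compound 2 `Cn1c(/C=C2/C(=O)Nc3ccc(Br)cc32)nc2ccccc21` likewise sits at the limit > 50000 nM in this assay. The step that the two limits leave unreadable from compound 1 to compound 2 cannot be sized since both values rest at the limit of > 50000 nM in this assay, at which 2 of the 3 values shown sit. Compound 4 `Cn1c(/C=C2/C(=O)Nc3ccc(Cl)cc32)nc2ccccc21` differs from compound 3 by methyl in place of isopropyl on an aromatic nitrogen. Within the data shown here, no measured step changes this group, so the data give no size or direction for it, and none of the three values shown points to strong inhibition. Compound 4 is therefore expected to give about 45000 nM, in the range 20000 nM to 100000 nM. That estimate means a step of a 1.2-fold higher number from compound 3 to compound 4 (0.07 log units; within the scatter) expected to lie within the scatter.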

Compound 4, half-maximal inhibitory concentration: > 50000 nM
Compound 4 was reported as a limit; the forecaster's own chance of this, stated with the estimate: 50%; middle value at least 1.1-fold (0.04 log units) away from the limit.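

At the aromatic nitrogen, methyl in place of isopropyl now has a measured step, an at least 1.3-fold higher number from compound 3 to compound 4 (0.11 log units; that floor lies within the scatter), so the change can be read only as a floor that does not clear the scatter. Compound 4 gives > 50000 nM, which is a limit of the assay and not a number. The steps from compound 1 and compound 2 to compound 4 cannot be read, because all three compounds rest at one limit: the limit of > 50000 nM in this assay, at which 3 of the 4 values shown sit.

Still open, from the compounds shown here alone, is how a longer chain, such as butyl, or a benzyl group on this nitrogen would read. Also open, going by these compounds, is how an amine would read in place of the chloro group.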